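The source may report more compounds than this note shows. Statements on the series, on what has been measured and on what is new or still open speak of the compounds shown alone.

Compound 1, `O=c1[nH]c(=O)n(CCC(CO)CO)cc1-c1ccco1`: in a functional assay on SW-620 cells (Homo sapiens) for antiproliferative activity, read by MTT assay, with a stated time of 72 h (a higher number here means a weaker inhibitor, a lower number a stronger inhibitor), compound 1 gives > 100000 nM, which is a limit of the assay rather than a number.
Compound 2, `CC(=O)OCC(CCn1cc(C#Cc2ccc(Br)cc2)c(=O)n(C(=O)c2ccccc2)c1=O)COC(C)=O`: in this assay compound 2 gives > 100000 nM, also a limit.
Compound 3, `CCCCCc1ccc(C#Cc2cn(CCC(COC(C)=O)COC(C)=O)c(=O)n(C(=O)c3ccccc3)c2=O)cc1`: in this assay compound 3 gives > 100000 nM, again a limit.

Every measured value here sits at the same point, (the limit of > 100000 nM in this assay, at which 3 of the 3 values shown sit), so compound 3 stands exactly where the other two stand: no number has been obtained for it, only a limit. For the measured compounds named here, the single measured step between neighbouring compounds, a step that the two limits leave unreadable from compound 2 to compound 3, is unreadable for the same reason, both of its ends being limits.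

Compound 4, `CCCCCCCCC#Cc1cn(CCC(COC(C)=O)COC(C)=O)c(=O)n(C(=O)c2ccccc2)c1=O`, differs from compound 3 in one place: octyl in place of 4-pentylphenyl on a triple-bonded carbon. Going by the values given here, no measured step bears on this change, because the only step available, a step that the two limits leave unreadable from compound 2 to compound 3, gives no readable size. With all three measured compounds at the limit, the most that can be expected is that compound 4 also remains there. Compound 4 is therefore expected to give an estimated 100000 nM, in a range from 30000 nM to 300000 nM. The expected step of a number no higher from compound 3 to compound 4 (the limit leaves the size open) is thus estimated as none beyond the scatter.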

Compound 4, half-maximal inhibitory concentration: 65800 nM
Estimate against measurement, compound 4: 1.5-fold (0.18 log units) above; low and high end bracket the measured number.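

For the compounds shown here, compound 4 is the first compound here to give a number rather than a limit in this assay, which shows that a readable value can be obtained with a chain and no ring on this triple-bonded carbon. Octyl in place of 4-pentylphenyl gives an at least 1.5-fold lower number from compound 3 to compound 4 (0.18 log units; that floor lies within the scatter), and octyl in place of 4-bromophenyl gives an at least 1.5-fold lower number from compound 2 to compound 4 (0.18 log units; that floor lies within the scatter). These are only floors, so the true size of each step is unknown, and the earlier compounds offer no number to set against compound 4: the limit of > 100000 nM in this assay, at which 3 of the 4 values shown sit.

Still open, from the compounds shown here alone, is how far either step really extends beyond its floor. Going by these compounds, it is also open whether a longer chain such as dodecyl, or an octyl chain ending in an amine or a carboxylic acid, would give a lower number than compound 4 at this triple-bonded carbon.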